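One flipped stereocentre on compound 1

This account rests on a few compounds, and the source may have more. Where it says the series, first, only, none or still open, it means among the compounds named here.

Going by the values given here, in a functional assay on EC9706 cells (Homo sapiens) for antiproliferative activity, read by MTT assay, with a stated time of 48 h (on this read-out lower numbers stand for stronger inhibition and higher numbers for weaker inhibition), compound 1 `CCCCCCCCn1cc(COC[C@@H]2OC[C@H](N)[C@@H]2O)nn1` gives 44300 nM, the highest of the three numbers so far. Compound 2 `CCCCCCCCCCn1cc(COC[C@@H]2OC[C@H](N)[C@@H]2O)nn1` gives 15600 nM, and compound 3 `CCCCCCCCCCCCCCCCCCn1cc(COC[C@@H]2OC[C@H](N)[C@@H]2O)nn1` gives 17800 nM. Compound 4 `CCCCCCCCn1cc(COC[C@@H]2OC[C@H](N)[C@H]2O)nn1` is still unmeasured. Its structure differs as follows: the two compounds have the same atoms and bonds and differ only in configuration as drawn: 1 of 3 stereo elements differ; a stereocentre at a saturated ring carbon is drawn S in compound 1 and R in compound 4. A stereocentre at a saturated ring carbon is drawn S in compound 1 and R in compound 4. Among the compounds with values here, no measured step changes configuration. The chain steps bear only indirectly: a 2.8-fold lower number from compound 1 to compound 2 (0.45 log units; beyond the scatter) and a 2.5-fold lower number from compound 1 to compound 3 (0.40 log units; beyond the scatter) are modest, while a 1.1-fold higher number from compound 2 to compound 3 (0.06 log units; within the scatter) lies within the scatter. They suggest no step beyond the scatter in this assay, in either direction, though this is uncertain. The expected change is a 1.1-fold lower number from compound 1 to compound 4 (0.04 log units; within the scatter). The estimate for compound 4 is 40000 nM, with an expected range of 15000 nM to 100000 nM.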

Compound 4, half-maximal inhibitory concentration: > 128000 nM
Compound 4 ended at the assay's limit; the forecaster's own chance of this, stated with the estimate: 8%; middle value at least 3.2-fold (0.50 log units) away from the limit.
By their numbers in this assay, from the lowest: compounds 2 and 3 (each within the scatter of the next); then compound 1. At a limit, above all of these: compound 4.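

In this assay, changing only one stereocentre at a saturated ring carbon, drawn S in compound 1 and R in compound 4, gives an at least 2.8-fold higher number from compound 1 to compound 4 (0.46 log units; beyond the scatter). Going by these compounds alone, the earlier steps changed only the chain, so this is the first sign that configuration alone can move the number beyond the scatter: the fact that compounds 1 and 4 differ only in the configuration as drawn. For compound 4, > 128000 nM is a limit of the assay, not a number: the limit of > 128000 nM in this assay, at which 1 of the 4 values shown sits.

Going by these compounds, whether the R configuration has a similar effect with the longer chains of compound 2 and compound 3 remains open. So does the effect of a fluorine at this carbon.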